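This account rests on a few compounds, and the source may have more. Where it says the series, first, only, none or still open, it means among the compounds named here.

Compound 1 `Cc1c(C)c2ccc(OC3CCN(C)CC3)cc2oc1=O` gives 11700 nM in an assay for inhibition of Amine oxidase [flavin-containing] A (Homo sapiens), read by fluorescence, using microsomes, with stated times of 20 min and 30 min; a lower number here means a stronger inhibitor, a higher number a weaker inhibitor. Compound 2 `CCCCN1CCC(Oc2ccc3c(C)c(C)c(=O)oc3c2)CC1` gives 23900 nM in this assay; the step of a 2.0-fold higher number from compound 1 to compound 2 (0.31 log units; beyond the scatter) is the only one measured so far. Compound 2 thus stands highest of the two numbers shown. Compound 3 `Cc1c(C)c2ccc(OC3CCN(Cc4ccc(C#N)cc4)CC3)cc2oc1=O` differs from compound 2 by 4-cyanophenyl in place of propyl on a saturated chain carbon bound to an amine nitrogen in a ring. Within the data shown here, only the step of a 2.0-fold higher number from compound 1 to compound 2 (0.31 log units; beyond the scatter) bears on this position, and it was modest; it concerned a chain growing by propyl, not an aromatic ring entering, so it carries little weight here. No step beyond the scatter is expected in this assay. Compound 3 is estimated at 20000 nM, range 6000 nM to 70000 nM, which means an expected step of a 1.2-fold lower number from compound 2 to compound 3 (0.08 log units; within the scatter).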

Compound 3, half-maximal inhibitory concentration: 1290 nM
Compound 3: the middle estimate sits 16-fold (1.19 log units) above what was measured, outside the stated range (below it).
By their numbers in this assay, from the lowest: compound 3; then compound 1; then compound 2.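

On the saturated chain carbon bound to the amine nitrogen in the ring, a larger group can lower the number: in this assay, 4-cyanophenyl in place of propyl gives a 19-fold lower number from compound 2 to compound 3 (1.27 log units; beyond the scatter), opposite in direction to the modest rise seen with propyl. Against hydrogen, the same group gives a 9.1-fold lower number from compound 1 to compound 3 (0.96 log units; beyond the scatter), so a chain and an aromatic ring at this position do not act alike in these compounds. No evidence at hand accounts for this difference.

Open, as far as these compounds go, is how the step divides between the aromatic ring and the nitrile; a plain benzyl on the same nitrogen would separate the two. Also open, from the compounds shown here alone, is whether the nitrile's place on the ring matters, as a 3-cyanobenzyl would show.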